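The compounds below may be only part of what the source reports. "The series", "measured", "known", "first", "only" and "open" are said of these compounds alone.

Compound 3 `COc1ccc(C(=O)/C=C/c2cc(-c3cc(OC)c(OC)c(OC)c3)n[nH]2)cc1` gives -6% in a functional assay on NCI/ADR-RES cells (Homo sapiens) for cytotoxicity, read by sulforhodamine B assay, with a stated time of 48 h, tested at 100 uM; a higher number here means a weaker effect of the compound at the concentration tested, a lower number a stronger effect. Among the three compounds measured, compound 3 stands second highest: compound 1 `COc1cc(-c2cc(/C=C/C(=O)c3ccc(Cl)c(Cl)c3)[nH]n2)cc(OC)c1OC` gives 5%, while compound 2 `COc1ccc(C(=O)/C=C/c2cc(-c3cc(OC)c(OC)c(OC)c3)n[nH]2)cc1OC` gives -40%. The gaps are a number 11 percentage points lower from compound 1 to compound 3 (beyond the scatter) and a number 34 percentage points higher from compound 2 to compound 3 (beyond the scatter), both beyond the usual scatter.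

Compound 4 `COc1cc(-c2cc(/C=C/C(=O)c3ccc(F)c(F)c3)[nH]n2)cc(OC)c1OC` differs from compound 3 in one place: 3,4-difluorophenyl in place of 4-methoxyphenyl on a carbonyl carbon. The measured step that bears most on this change is the one where two chlorines on that ring gave way to a single methoxy group and the number fell modestly, as seen between compound 1 and compound 3. Moving from compound 3 to compound 4 puts two halogens back on that carbonyl carbon, fluorine rather than chlorine, so a modest rise toward the number of compound 1 is expected, with a number 8 percentage points higher from compound 3 to compound 4 (within the scatter). For the measured compounds named here, the large drop of a number 45 percentage points lower from compound 1 to compound 2 (beyond the scatter) shows how strongly two methoxy groups on that ring pull the number down, but no difluoro compound has yet been measured, so the expectation is uncertain. Compound 4 is therefore expected to give 2%, within a range from -15% to 18%.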

Compound 4, a percentage reported as activity, at one concentration (the size of the read-out at that concentration, not a potency): -5%
Estimate against measurement, compound 4: 7 percentage points above; low and high end bracket the measured number.
By their numbers in this assay, from the lowest: compound 2; then compounds 3, 4 and 1 (each within the scatter of the next, the first and the last beyond it).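

In this assay, the 3,4-difluorophenyl group on the carbonyl carbon cannot be told apart from the 4-methoxyphenyl group (a number 1 percentage points higher from compound 3 to compound 4 (within the scatter)) or from the 3,4-dichlorophenyl group (a number 10 percentage points lower from compound 1 to compound 4 (within the scatter)). The 3,4-dimethoxyphenyl group does stand apart from it (a number 35 percentage points higher from compound 2 to compound 4 (beyond the scatter)), so among the four compounds, compound 2 alone is clearly separated from the new compound, and replacing chlorine with fluorine on this ring produces no step beyond the scatter. No measurement at hand explains these results. On these data alone, it remains open whether the stronger effect of compound 2 needs both methoxy groups or would also appear with other groups on that ring, such as an amine or a carboxylic acid. A longer chain, such as ethoxy in place of methoxy, is also untested among the compounds shown.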